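A few compounds are considered here, and "the series" means these few. Any claim that something is new, unique, unknown or untested is made for them only; others in the source may bear on it.

Compound 2 `COc1cc(-c2nn(-c3cccc(NC(=O)Nc4ccc(Cl)c(Cl)c4)c3)cc2-c2ccncc2)ccc1Cl` is the starting point of this step. In a functional assay on OVCAR-4 cells (Homo sapiens) for inhibition, read by sulforhodamine B assay, with a stated time of 48 h (on this read-out higher numbers stand for weaker inhibition of growth and lower numbers for stronger inhibition of growth), compound 2 gives 1290 nM, the second highest of the three numbers recorded; compound 1 `COc1cc(-c2nn(-c3cccc(NC(=O)Nc4cc(C(F)(F)F)cc(C(F)(F)F)c4)c3)cc2-c2ccncc2)ccc1Cl` gives 1120 nM, and compound 3 `O=C(Nc1cccc(-n2cc(-c3ccncc3)c(-c3ccc(Cl)c(O)c3)n2)c1)Nc1ccc(Cl)c(Cl)c1` gives 1690 nM. All three numbers lie within the usual scatter of one another, so none of them can be set apart.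

Compound 4 `COc1cc(-c2nn(-c3cccc(NC(=O)c4ccc(Cl)c(C(F)(F)F)c4)c3)cc2-c2ccncc2)ccc1Cl` arises from compound 2 by 4-chloro-3-(trifluoromethyl)phenyl in place of (3,4-dichlorophenyl)amino on a carbonyl carbon. Going by the values given here, no measured step shares this change. Among the compounds with values here, the only measured step, from compound 2 to compound 3, concerns a different change, hydrogen in place of methyl on an oxygen on an aromatic ring, and amounts to a 1.3-fold higher number from compound 2 to compound 3 (0.12 log units; within the scatter). The pair compound 1 and compound 2 differ in the substitution of the ring on the amide-type nitrogen, and their values sit within the scatter, which suggests that change in that part of the molecule has so far left the number roughly where it was.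

On this basis compound 4 is expected to show no step beyond the scatter in this assay, the estimated step being a 1.0-fold higher number from compound 2 to compound 4 (0.00 log units; within the scatter). The estimated value for compound 4 is 1300 nM, with a range from 450 nM to 3800 nM.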

Compound 4, concentration for 50% growth inhibition: 8040 nM
Compound 4: the middle estimate sits 6.2-fold (0.79 log units) below what was measured, and the stated range ends below it.
By their numbers in this assay, from the lowest: compounds 1, 2 and 3 (each within the scatter of the next); then compound 4.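

In this assay, going by these compounds alone, 4-chloro-3-(trifluoromethyl)phenyl in place of (3,4-dichlorophenyl)amino gives a 6.2-fold higher number from compound 2 to compound 4 (0.79 log units; beyond the scatter) and is thus the first step in this set to lie beyond the scatter, in the direction of weaker inhibition of growth. The number therefore responds to a change on this carbonyl carbon, whose other neighbour is the amide-type nitrogen. The change removes the amino nitrogen and alters the ring substituents at once, so this single step cannot separate the two, and no evidence on its cause is at hand.

The compounds shown therefore leave open whether the loss of the amino nitrogen or the change of ring substituents accounts for the step. On these data alone, how a methylene link or a piperazine on this carbonyl carbon would read in this assay also remains open.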